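Adding a Second Fluorine to a Weakly Cytotoxic Compound

The compounds below may be only part of what the source reports. "The series", "measured", "known", "first", "only" and "open" are said of these compounds alone.

Compound 1 and compound 2, built on a shared core, have so far been tested in a functional assay on A549 cells (Homo sapiens) for cytotoxicity, read by MTT assay, with a stated time of 72 h; on this read-out higher numbers stand for weaker inhibition and lower numbers for stronger inhibition. Compound 1, `O=C(Nc1ccc(Oc2ccnc3[nH]ccc23)cc1)c1nn(-c2ccc(Br)cc2F)ccc1=O`, gives 26100 nM in this assay. Compound 2, `O=C(Nc1ccc(Oc2ccnc3[nH]ccc23)c(F)c1)c1nn(-c2ccc(Br)cc2)ccc1=O`, reaches only a limit in this assay, reported as > 60000 nM, so no number is known for it. Compound 2 therefore stands at the limit of > 60000 nM in this assay, at which 1 of the 2 values shown sits.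

Compound 3, `O=C(Nc1ccc(Oc2ccnc3[nH]ccc23)c(F)c1)c1nn(-c2ccc(Br)cc2F)ccc1=O`, is compound 2 with one change: fluoro in place of hydrogen on an aromatic carbon. For the measured compounds named here, no pair of measured compounds shows this single change on its own, so the size of its effect is not known from these data. Going by the values given here, compound 1, which carries the same 4-bromo-2-fluorophenyl group without the fluoro on the aniline ring, is the only other point of comparison. Compound 3 is expected to remain weak, around 45000 nM, within a range of 15000 nM to 120000 nM. The step of an at least 1.3-fold lower number from compound 2 to compound 3 (0.12 log units; that floor lies within the scatter) is estimated to be small, no larger than the usual scatter, with a fair chance that only a limit is reported again.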

Compound 3, half-maximal inhibitory concentration: 55700 nM
Compound 3: middle estimate off by 1.2-fold (0.09 log units), on the low side; the range from low to high includes it.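

The step from compound 1 shows that placing fluoro in the second position can matter: in this assay, fluoro in place of hydrogen on an aromatic carbon gives a 2.1-fold higher number from compound 1 to compound 3 (0.33 log units; beyond the scatter), a modest weakening. The change from 4-bromophenyl to 4-bromo-2-fluorophenyl, ortho to a large group, gives an at least 1.0-fold lower number from compound 2 to compound 3 (0.03 log units; that floor lies within the scatter), so it shows no firm gain in cytotoxicity. Compound 2 has only a limit and not a number, which leaves the true size of that step unknown: the limit of > 60000 nM in this assay, at which 1 of the 3 values shown sits.

The compounds shown leave open how a chloro, methyl or methoxy group would compare with fluoro at either place in this assay. They also leave open whether the modest weakening from compound 1 to compound 3 would carry over to another core.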